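Pyrimidine for pyridine on an inactive oxadiazole series

This account rests on a few compounds, and the source may have more. Where it says the series, first, only, none or still open, it means among the compounds named here.

Compound 1 `Cc1cccc(-c2nnc([C@H](C)NC(=O)c3cc(C4CC4)nn3C)o2)c1` reaches only the assay limit in an assay on T-REx-293 cells for inhibition of potassium channel subfamily T member 1 (Homo sapiens), read by patch clamp (on this read-out higher numbers stand for weaker inhibition and lower numbers for stronger inhibition), recorded as > 30000 nM. Compound 2 `C[C@H](NS(=O)(=O)c1cc(C(F)(F)F)nn1C)c1nc(-c2cccc(F)c2)no1` likewise returns a limit of > 30000 nM. Compound 3 `Cc1cccc(-c2noc([C@H](C)NC(=O)c3cc(C(F)(F)F)nn3C)n2)n1` stands at the same limit, > 30000 nM. No numbered value exists anywhere in the set; all three sit at the limit of > 30000 nM in this assay, at which 3 of the 3 values shown sit, so no ranking among them can be drawn.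

Compound 4 `Cc1cc(-c2noc([C@H](C)NC(=O)c3cc(C(F)(F)F)nn3C)n2)ncn1` carries 6-methylpyrimidin-4-yl in place of 6-methylpyridin-2-yl on an aromatic carbon, a change that keeps the rest of the molecule intact. Among the measured compounds shown here, with every value so far a limit and no measured step available, a shift beyond the scatter is expected neither upward nor downward; compound 4 is expected to remain at the limit as well, the estimated step from compound 3 being a step that the limit leaves unreadable from compound 3 to compound 4. The estimate for compound 4 in this assay is 40000 nM, with a range from 10000 nM to 100000 nM.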

Compound 4, half-maximal inhibitory concentration: 1410 nM
Compound 4: the middle estimate sits 28-fold (1.45 log units) above what was measured, outside the stated range (below it).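

In this assay, the aromatic carbon between two ring nitrogen atoms proves able to move the read-out: 6-methylpyrimidin-4-yl in place of 6-methylpyridin-2-yl gives an at least 21-fold lower number from compound 3 to compound 4 (1.32 log units; beyond the scatter). Among the compounds shown here, compound 4 is the first compound here with a value off the limit, so the series is not uniformly inactive. The step stays a bound, because compound 3 carries only a limit: the limit of > 30000 nM in this assay, at which 3 of the 4 values shown sit.

As far as these compounds go, whether 6-methylpyrimidin-4-yl has a similar effect alongside the cyclopropyl of compound 1 or the sulfonamide of compound 2 stays open. Also open, from the compounds shown here alone, is how an amine in place of the methyl would read.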